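A Side Chain Exchange on Compound 3

The compounds below may be only part of what the source reports. "The series", "measured", "known", "first", "only" and "open" are said of these compounds alone.

Measured in a toxicity assay on B16-F10 cells (Mus musculus) for cytotoxicity, read by CCK-8 assay, with stated times of 16 h and 24 h; on this read-out lower numbers stand for stronger inhibition and higher numbers for weaker inhibition:
- compound 1 `COc1ccc(C2=[N+]3C(=Nc4c(-c5ccccc5)c5c(n4[B-]3(F)F)-c3ccc(OCC(=O)O)cc3CC5)C(c3ccccc3)=C2I)cc1`: 104 nM
- compound 2 `COc1ccc(C2=[N+]3C(=Nc4c(-c5ccccc5)c5c(n4[B-]3(F)F)-c3ccc(OCC(=O)N[C@@H](CC(=O)O)C(=O)O)cc3CC5)C(c3ccccc3)=C2I)cc1`: 65 nM
- compound 3 `COc1ccc2c(c1)CCc1c(-c3ccccc3)c3n(c1-2)[B-](F)(F)[N+]1=C(c2ccc(OCC(=O)O)cc2)C(I)=C(c2ccccc2)C1=N3`: 346 nM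

Lower numbers mean stronger inhibition here, so compound 3, with 346 nM, is the weakest of the three, and its gaps to the other two exceed the usual scatter of repeat measurements.

Compound 4 `COc1ccc2c(c1)CCc1c(-c3ccccc3)c3n(c1-2)[B-](F)(F)[N+]1=C(c2ccc(OCC(=O)N[C@@H](CC(=O)O)C(=O)O)cc2)C(I)=C(c2ccccc2)C1=N3` differs from compound 3 in one place: (1,2-dicarboxyethyl)amino in place of hydroxy on a carbonyl carbon. Cut one bond further out, carboxy becomes (1,2-dicarboxyethyl)carbamoyl.

The identical exchange has been measured only once, in the step of a 1.6-fold lower number from compound 1 to compound 2 (0.20 log units; within the scatter). That step is small and does not clear the scatter. Compound 1 also differs in structure from compound 3, so this single precedent may not carry over, and it establishes no pattern. A modest lowering in this assay is therefore the most that can be expected, with no shift beyond the scatter. The estimated change is a 1.5-fold lower number from compound 3 to compound 4 (0.19 log units; within the scatter). For compound 4 the expected value is 225 nM, with an estimated range of 110 nM to 450 nM.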

Compound 4, half-maximal inhibitory concentration: 126 nM
Estimate against measurement, compound 4: 1.8-fold (0.25 log units) above; low and high end bracket the measured number.
By their numbers in this assay, from the lowest: compounds 2, 1 and 4 (each within the scatter of the next); then compound 3.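

On the core of compound 3, the exchange of hydroxy for (1,2-dicarboxyethyl)amino on the carbonyl carbon gives, in this assay, a 2.7-fold lower number from compound 3 to compound 4 (0.44 log units; beyond the scatter), so this change now produces a step that clears the usual scatter. Going by these compounds alone, the only earlier example, a 1.6-fold lower number from compound 1 to compound 2 (0.20 log units; within the scatter), could not be told apart from repeat-to-repeat variation, and it left open whether the exchange does anything measurable at all. The second example shows that it can, and that this much larger group is accepted at this position on both cores without the number rising, although the data cannot say that one core responds more than the other, as the two steps agree within their combined scatter: the same change on two cores in this assay, a 1.6-fold lower number (0.20 log units; within the scatter) from compound 1 to compound 2 and a 2.7-fold lower number (0.44 log units; beyond the scatter) from compound 3 to compound 4, 1.7-fold (0.23 log units) apart, within the scatter of two such steps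

The compounds shown carry only this one replacement, so they leave open whether a group with a single carboxylic acid, or a plain methylamino group on the same carbonyl carbon, would give a step of similar size. Also open, on these data alone, is whether the opposite arrangement at the defined stereocentre of the (1,2-dicarboxyethyl)amino group would give the same number.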